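Thioether series: cytotoxicity notes on four compounds

The source may report more compounds than this note shows. Statements on the series, on what has been measured and on what is new or still open speak of the compounds shown alone.

Measured so far:
Compound 1 `Cc1ccc(C(=O)CSc2nnc(C)n2N2C(=O)c3ccccc3C2=O)cc1` in a functional assay on HepG2 cells (Homo sapiens) for cytotoxicity, read by MTT assay, with a stated time of 48 h; on this read-out higher numbers stand for weaker inhibition and lower numbers for stronger inhibition: compound 1 gives > 200000 nM, a limit of the assay and not a number.
Compound 2 `C#CCSc1nnc(C)n1N1C(=O)c2ccccc2C1=O`: compound 2 gives > 200000 nM, again a limit.
Compound 3 `CCCc1nnc(SCC(=O)c2ccc(C)cc2)n1N1C(=O)c2ccccc2C1=O`: compound 3 gives > 200000 nM, also a limit.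

Compound 3 is set apart from compound 1 by ethyl in place of hydrogen on a saturated chain carbon bound to an aromatic carbon, so the two cores differ in that one place. The change from compound 1 to compound 2 is ethynyl in place of (4-methylphenyl)carbonyl on a saturated chain carbon bound to a sulfur, and the step it made is a step that the two limits leave unreadable from compound 1 to compound 2. The step that the two limits leave unreadable from compound 1 to compound 3 is unreadable for the same reason: all three values sit at the limit of > 200000 nM in this assay, at which 3 of the 3 values shown sit.

Compound 4 `C#CCSc1nnc(CCC)n1N1C(=O)c2ccccc2C1=O` is not yet measured. It differs from compound 3 by ethynyl in place of (4-methylphenyl)carbonyl on a saturated chain carbon bound to a sulfur, the same change, at the same place, as from compound 1 to compound 2. Within the data shown here, since every value so far is a limit, the step that the limit leaves unreadable from compound 3 to compound 4 is expected to stay unreadable as well. For compound 4 the estimate in this assay is 300000 nM, most likely reported as a limit rather than a number.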

Compound 4, half-maximal inhibitory concentration: > 200000 nM
Compound 4: only a limit was reported (the forecaster's own chance of this, stated with the estimate: 85%); the middle value is on the limit's open side.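

In this assay compound 4 gives > 200000 nM, a limit and not a number, so no new step can be read from compound 2 or compound 3 to compound 4: the limit of > 200000 nM in this assay, at which 4 of the 4 values shown sit.

The compounds shown leave open how large the effect of either change, ethynyl for (4-methylphenyl)carbonyl or ethyl for hydrogen, is on cytotoxicity in this assay once a value falls inside the measurable range.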